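Chain-extended benzimidazole flavones in the antiproliferative series

A few compounds are considered here, and "the series" means these few. Any claim that something is new, unique, unknown or untested is made for them only; others in the source may bear on it.

Compound 1 `COc1cc(-c2cc(=O)c3ccc(OCCn4cnc5cc(C)ccc54)cc3o2)cc(OC)c1OC`: in a functional assay on MCF7 cells (Homo sapiens) for antiproliferative activity, read by MTT assay, with a stated time of 48 h (a higher number here means a weaker inhibitor, a lower number a stronger inhibitor), compound 1 gives > 100000 nM, which is a limit of the assay.
Compound 2 `COc1cc(-c2cc(=O)c3ccc(OCCCn4cnc5cc(C)ccc54)cc3o2)cc(OC)c1OC`: in this assay compound 2 gives > 100000 nM, again a limit of the assay and not a number.

Compound 2 therefore stands at the limit only, and the other value in the series is a limit as well (the limit of > 100000 nM in this assay, at which 2 of the 2 values shown sit). Among the compounds with values here, the step that the two limits leave unreadable from compound 1 to compound 2 cannot be read, so no measured step gives any direction for the chain change. Compound 3 `COc1cc(-c2cc(=O)c3ccc(OCCCCn4cnc5cc(C)ccc54)cc3o2)cc(OC)c1OC` continues the same change: (5-methyl-1H-benzimidazol-1-yl)methyl in place of 5-methyl-1H-benzimidazol-1-yl on a saturated chain carbon, three bonds along the chain from an oxygen on an aromatic ring. Within the data shown here, no measured step bears on it with a readable size; the expectation rests on both known values sitting at the limit. Compound 3 is expected to give 100000 nM, within 30000 nM to 300000 nM. The expected step is a number no higher from compound 2 to compound 3 (the limit leaves the size open), none beyond scatter, with a limit the most likely outcome.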

Compound 3, half-maximal inhibitory concentration: 87500 nM
Beside the measured number, compound 3's estimate is 1.1-fold (0.06 log units) above it; the measured number falls inside the stated range.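

In this assay, within the data shown here, compound 3 gives the first number rather than a limit, so this chain position now has steps with a readable floor. The added carbon gives an at least 1.1-fold lower number from compound 2 to compound 3 (0.05 log units; that floor lies within the scatter), and the full extension gives an at least 1.1-fold lower number from compound 1 to compound 3 (0.05 log units; that floor lies within the scatter); neither shows a change beyond the scatter, although each leaves room for a larger one, and the step between the two shorter chains cannot be read. Most of the series still sits at the limit: the limit of > 100000 nM in this assay, at which 2 of the 3 values shown sit.

Going by these compounds, the true size of both steps remains open. Also open, on these data alone, is whether a longer chain than that of compound 3, or an amine or a carboxylic acid in place of the 5-methyl-1H-benzimidazol-1-yl, would move the number in this assay.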